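This account rests on a few compounds, and the source may have more. Where it says the series, first, only, none or still open, it means among the compounds named here.

Three compounds share a core that carries a naphthyl group and an oxime ether, and differ only in the aryl group attached to the saturated chain carbon of that ether. Compound 1 `C(=N/OCc1ccccc1)\c1c(-c2ccc3ccccc3c2)nc2occn12` gives 840 nM in an assay on HepG2 cells for agonist activity at nuclear receptor subfamily 1 group I member 3 (Homo sapiens), read by a luciferase reporter, with a stated time of 23 h; on this read-out lower numbers stand for an effect already at smaller amounts and higher numbers for an effect only at larger amounts of compound. Compound 2 `FC(F)(F)c1ccc(CO/N=C/c2c(-c3ccc4ccccc4c3)nc3occn23)cc1` gives 470 nM in this assay, and compound 3 `Fc1c(F)c(F)c(CO/N=C/c2c(-c3ccc4ccccc4c3)nc3occn23)c(F)c1F` gives 1700 nM in this assay, the highest of the three numbers. The steps leading to compound 3 are a 2.0-fold higher number from compound 1 to compound 3 (0.31 log units; beyond the scatter) and a 3.6-fold higher number from compound 2 to compound 3 (0.56 log units; beyond the scatter), whereas the step of a 1.8-fold lower number from compound 1 to compound 2 (0.25 log units; within the scatter) stays within the scatter.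

Compound 4 `Clc1ccc(CO/N=C/c2c(-c3ccc4ccccc4c3)nc3occn23)cc1` is not yet measured. It differs from compound 3 as follows: 4-chlorophenyl in place of 2,3,4,5,6-pentafluorophenyl on a saturated chain carbon bound to an oxygen on an unsaturated carbon. Since leaving the pentafluorophenyl for phenyl or 4-(trifluoromethyl)phenyl gave lower numbers in both measured steps, a return to a singly substituted phenyl is expected to bring the number back down toward those of compound 1 and compound 2. Compound 4 is therefore expected to show a 3.1-fold lower number from compound 3 to compound 4 (0.49 log units; beyond the scatter), with an estimate of 550 nM in this assay, ranging from 250 nM to 1200 nM.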

Compound 4, half-maximal effective concentration: 990 nM
The estimate for compound 4 lay 1.8-fold (0.26 log units) below the measured number; low and high end bracket the measured number.
By their numbers in this assay, from the lowest: compounds 2, 1, 4 and 3 (each within the scatter of the next, the first and the last beyond it).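

In this assay, the 4-chlorophenyl group on the saturated chain carbon cannot be told apart from the plain phenyl ring (a 1.2-fold higher number from compound 1 to compound 4 (0.07 log units; within the scatter)) or from the 2,3,4,5,6-pentafluorophenyl group (a 1.7-fold lower number from compound 3 to compound 4 (0.23 log units; within the scatter)), so the gap seen earlier for the fully fluorinated ring is not matched by a clear gap for this chlorinated ring. Only the exchange of trifluoromethyl for chloro leaves the scatter (a 2.1-fold higher number from compound 2 to compound 4 (0.32 log units; beyond the scatter)), which shows that two single substituents on the same ring carbon can be told apart even though neither can be told apart from hydrogen. No data here explain why these two substituents differ.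

The compounds shown leave open how an amine or a carboxylic acid on this ring would read in this assay. They also leave open what a longer chain in place of the saturated chain carbon would do.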